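From Benzylamino to Cyclohexylamino on a Shared Core

The compounds below may be only part of what the source reports. "The series", "measured", "known", "first", "only" and "open" are said of these compounds alone.

- Compound 1 `O=C1C=C(NCc2ccccc2)C(=O)c2c1nc1n2[C@H]2OC[C@@H](O)[C@H]2OC1` gives 2670 nM in this series
- Compound 2 `Cc1ccc(NC2=CC(=O)c3c(nc4n3[C@H]3OC[C@@H](O)[C@H]3OC4)C2=O)cc1` gives 1550 nM in this series

Both values come from a functional assay on MGC-803 cells (Homo sapiens) for inhibition, read by sulforhodamine B assay (a lower number here means a stronger inhibitor, a higher number a weaker inhibitor), and lie within the scatter of each other, so the data do not separate compound 1 from compound 2. Among the measured compounds shown here, compound 1 therefore stands alongside the only other measured compound, and neither can be called the better of the two.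

Compound 3 `O=C1C=C(NC2CCCCC2)C(=O)c2c1nc1n2[C@H]2OC[C@@H](O)[C@H]2OC1` has not yet been measured. It keeps the core of compound 1 and differs at one place, with cyclohexyl in place of benzyl on an amine nitrogen is the whole of the difference.

For the measured compounds named here, no pair of measured compounds shows this change, so the data offer no direct measure of its size. The expectation rests on compound 1 at 2670 nM as the starting point, and no step beyond the scatter is expected in this assay in either direction. The estimated step is a 1.1-fold lower number from compound 1 to compound 3 (0.03 log units; within the scatter) and it is expected to stay within the scatter. Compound 3 is estimated at 2500 nM with 1000 nM to 6500 nM as the expected range.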

Compound 3, half-maximal inhibitory concentration: > 8000 nM
Compound 3 ended at the assay's limit (the forecaster's own chance of this, stated with the estimate: 3%); middle value at least 3.2-fold (0.50 log units) away from the limit.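

In this assay compound 3 gives > 8000 nM, which is a limit of the assay and not a number: the limit of > 8000 nM in this assay, at which 1 of the 3 values shown sits. Cyclohexyl in place of benzyl on the amine nitrogen comes with an at least 2.9-fold higher number from compound 1 to compound 3 (0.47 log units; beyond the scatter), the first step in this set that can be read at all, and it lies beyond the scatter. The position is therefore not indifferent to what is attached there: on the shared core, this swap of one carbon ring for another is enough to move the read-out in the direction of a weaker inhibitor.

The compounds shown leave open how large the step really is, and whether it follows the loss of the aromatic ring or the change in how the ring is joined to the nitrogen, as the two come together in this single swap. A cyclohexylmethyl group on the same amine nitrogen, or an open carbon chain such as butyl, would bear on that question, and neither stands among these compounds.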